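Series notes: from compound 3 to compound 4

The compounds below may be only part of what the source reports. "The series", "measured", "known", "first", "only" and "open" are said of these compounds alone.

Of the compounds shown here, three sharing one core have been measured in an assay on PMNL cells for inhibition of Polyunsaturated fatty acid 5-lipoxygenase (Homo sapiens), read by HPLC, with stated times of 5 min and 15 min; a higher number here means a weaker inhibitor, a lower number a stronger inhibitor. Compound 1 `COc1cc(/C=C/C(=O)OCCc2cccc(F)c2)cc(OC)c1O` gives 230 nM. Compound 2 `COc1cc(/C=C/COCc2ccccc2)cc(OC)c1O` gives 1100 nM. Compound 3 `COc1cc(/C=C/c2nc(Cc3ccccc3)no2)cc(OC)c1O` gives 300 nM, the second highest of the three numbers; against compound 1 the gap lies within the scatter, against compound 2 it lies beyond it. Going by the values given here, no measured pair differs in one place only, so no step size is known from the data. Compound 4 `COc1cc(/C=C/c2nc(CCc3ccccc3)no2)cc(OC)c1O` carries benzyl in place of phenyl on a saturated chain carbon bound to an aromatic carbon. A step of this kind is expected to stay small, with no direction beyond the scatter. For compound 4 the expected value in this assay is 300 nM, with a range from 120 nM to 800 nM. The expected step is no change at the digits printed from compound 3 to compound 4 (within the scatter).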

Compound 4, half-maximal inhibitory concentration: 270 nM
Estimate against measurement, compound 4: 1.1-fold (0.05 log units) above, within the range that was stated.
By their numbers in this assay, from the lowest: compounds 1, 4 and 3 (each within the scatter of the next); then compound 2.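

In this assay, going by these compounds alone, benzyl in place of phenyl on a saturated chain carbon bound to an aromatic carbon gives a 1.1-fold lower number from compound 3 to compound 4 (0.05 log units; within the scatter), the first step that can be read at a single place. At this place, then, the difference of benzyl to phenethyl leaves the number unchanged within the scatter. Nothing available offers an account of this result. 

Open, on these data alone, is whether a longer chain, such as phenylpropyl, would also leave the number within the scatter. Also open, as far as these compounds go, is whether an amine or a carboxylic acid at the same place would move it.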